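A few compounds are considered here, and "the series" means these few. Any claim that something is new, unique, unknown or untested is made for them only; others in the source may bear on it.

Compound 2, `CN1CCN(/N=N/c2ccccc2)CC1`, gives > 100000 nM in an ADME assay on MDBK cells (Bos taurus) for cytotoxicity, read by MTT assay, with a stated time of 96 h (a lower number here means that less compound is tolerated, a higher number that more compound is tolerated), which is a limit of the assay and not a number. Compound 1, `c1ccc(/N=N/N2CCN(c3ccccc3)CC2)cc1`, gives > 100000 nM, also a limit. Going by the values given here, the series so far rests on (the limit of > 100000 nM in this assay, at which 2 of the 2 values shown sit). Among the compounds with values here, the one measured step, a step that the two limits leave unreadable from compound 1 to compound 2, therefore offers no size to carry forward. Compound 3, `c1ccc(/N=N/N2CCN(c3ncccn3)CC2)cc1`, differs from compound 2 by pyrimidin-2-yl in place of methyl on an amine nitrogen in a ring. With no readable step, no change beyond the scatter is expected in this assay, and the expected step is a number no higher from compound 2 to compound 3 (the limit leaves the size open). Compound 3 is estimated at 100000 nM, with an expected range of 40000 nM to 200000 nM.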

Compound 3, half-maximal cytotoxic concentration: > 100000 nM
Compound 3 ended at the assay's limit (the forecaster's own chance of this, stated with the estimate: 75%); the middle value sits exactly at the limit.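

Going by these compounds alone, compound 3 also ends at a limit of the assay, so no step among compound 1, compound 2 and compound 3 can be read: the limit of > 100000 nM in this assay, at which 3 of the 3 values shown sit. The compounds shown leave open which group on that amine nitrogen, if any, would give a readable value in this assay.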